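The compounds below may be only part of what the source reports. "The series", "measured", "known", "first", "only" and "open" are said of these compounds alone.

The series rests on a shared core, seen in compound 1 `N=C(NO)N/N=C/c1ccccc1Cl` and compound 2 `N/C(=N\O)N/N=C/c1ccccc1O`. In a functional assay on HL-60 cells (Homo sapiens) for antiproliferative activity (on this read-out lower numbers stand for stronger inhibition and higher numbers for weaker inhibition), compound 1 gives 60000 nM, the lowest of the two numbers recorded; compound 2 gives 95000 nM, and the two values sit within the scatter of each other, so no order between them can be read. Compound 3 `N=C(NO)N/N=C/c1ccccc1` has not yet been measured. It differs from compound 1 by hydrogen in place of chloro on an aromatic carbon. Going by the values given here, no pair of measured compounds separated by a single change exists here, so the size of this step cannot be anchored to an observed one. With both measured values weak, loss of the chloro is expected to move the number little; the expected step is a 1.5-fold higher number from compound 1 to compound 3 (0.18 log units; within the scatter), a modest shift toward weaker inhibition if anything beyond the scatter. Compound 3 is accordingly estimated at 90000 nM in this assay, within a range from 40000 nM to 200000 nM.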

Compound 3, half-maximal inhibitory concentration: 62000 nM
For compound 3 the middle estimate is 1.5-fold (0.16 log units) above the measured one, within the range that was stated.
By their numbers in this assay, from the lowest: compounds 1, 3 and 2 (each within the scatter of the next).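

In this assay, hydrogen in place of chloro on the aromatic carbon gives a 1.0-fold higher number from compound 1 to compound 3 (0.01 log units; within the scatter), the first single-change step available for this series. At this position, ortho to a group of 7 heavy atoms, the chloro can therefore be removed without a readable change: compound 3, which carries only hydrogen there, gives 62000 nM and remains in the same weak range as compound 1. Nothing measured here offers an explanation for this flat step.

Going by these compounds, it remains open whether any group on this carbon can move the number beyond the scatter, for example an amine, a carboxylic acid or a methoxy group. Also open, on these data alone, is whether a change to the shared core, such as a longer chain in place of the ring, would shift the read-out.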